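A hydroxyl at the end of a disulfide chain

The compounds below may be only part of what the source reports. "The series", "measured", "known", "first", "only" and "open" are said of these compounds alone.

Three disulfides of the shared core have been measured in a physicochemical assay for metabolic stability, in the presence of a further agent that is not named here; on this read-out lower numbers stand for a shorter-lived compound and higher numbers for a longer-lived compound. Compound 1 `Cc1cn([C@H]2C[C@H](SSC(Cl)(Cl)Cl)[C@@H](CO)O2)c(=O)[nH]c1=O` carries a trichloromethyl on the outer sulfur; in this assay compound 1 gives only a limit, < 1.5 h. Compound 2 `C=CCSS[C@H]1C[C@H](n2cc(C)c(=O)[nH]c2=O)O[C@@H]1CO` carries an allyl on that sulfur; in this assay compound 2 gives a limit as well, < 8 h. Compound 3 `CCCCCCCCSS[C@H]1C[C@H](n2cc(C)c(=O)[nH]c2=O)O[C@@H]1CO` carries an octyl on that sulfur; in this assay compound 3 gives a limit too, < 8 h. Compound 3 therefore stands at a limit, and the limit of < 1.5 h in this assay, at which 1 of the 3 values shown sits, together with the limit of < 8 h in this assay, at which 2 of the 3 values shown sit, is all that is known of the set. The steps a step that the two limits leave unreadable from compound 1 to compound 2, a step that the two limits leave unreadable from compound 1 to compound 3 and a step that the two limits leave unreadable from compound 2 to compound 3 carry no readable size. Compound 4 `Cc1cn([C@H]2C[C@H](SSCCCCCCO)[C@@H](CO)O2)c(=O)[nH]c1=O` differs from compound 3 by hydroxy in place of ethyl on a saturated chain carbon, six bonds along the chain from a sulfur. Among the measured compounds shown here, none of the measured steps has a readable size, so neither a direction nor a size for the step from compound 3 to compound 4 can be drawn from them. Compound 4 is therefore expected to remain near a limit, estimated at 4 h within 1.5 h to 8 h. The step that the limit leaves unreadable from compound 3 to compound 4 is accordingly expected to be small.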

Compound 4, half-life: < 8 h
Compound 4: a limit, no number; the forecaster's own chance of this, stated with the estimate: 60%; the middle value does not contradict the limit.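

Compound 4 also gives only a limit in this assay, so its steps from compound 1, compound 2 and compound 3 cannot be read. The compounds shown leave open the actual half-life of all four, and whether hydroxy in place of ethyl shifts it at all.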